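This account rests on a few compounds, and the source may have more. Where it says the series, first, only, none or still open, it means among the compounds named here.

Measured compounds: compound 1 `O=C(COc1ccc2cc(/C=C3/SC(=O)NC3=O)ccc2c1)Nc1cccc(F)n1` gives 840 nM in an assay on isolated protein for inhibition of histone deacetylase 4 (Homo sapiens), with a stated time of 1 h; a higher number here means a weaker inhibitor, a lower number a stronger inhibitor; compound 2 `O=C(COc1ccc2cc(/C=C3/SC(=O)NC3=O)ccc2c1)Nc1ccc(F)cc1F` gives 3900 nM; compound 3 `Cc1cccc2sc(NC(=O)COc3ccc4cc(/C=C5/SC(=O)NC5=O)ccc4c3)nc12` gives 1200 nM.

Compound 3 holds the second highest of the three numbers in this assay. The step of a 1.4-fold higher number from compound 1 to compound 3 (0.15 log units; within the scatter) stays within the scatter, whereas a 3.3-fold lower number from compound 2 to compound 3 (0.51 log units; beyond the scatter) lies beyond it. Compound 4 `O=C(COc1ccc2cc(/C=C3/SC(=O)NC3=O)ccc2c1)Nc1ccc(Cl)c(Cl)c1` arises from compound 3 by 3,4-dichlorophenyl in place of 4-methyl-1,3-benzothiazol-2-yl on an amide-type nitrogen. Among the compounds with values here, two measured steps bear on this change, a 4.6-fold higher number from compound 1 to compound 2 (0.67 log units; beyond the scatter) and a 3.3-fold lower number from compound 2 to compound 3 (0.51 log units; beyond the scatter); in both, the 2,4-difluorophenyl amide carries the higher number, and compound 4 again places a dihalogenated phenyl on the amide-type nitrogen. Compound 4 is therefore expected to show a modest rise, a 2.2-fold higher number from compound 3 to compound 4 (0.34 log units; beyond the scatter). The estimate for compound 4 in this assay is 2600 nM, within a range from 900 nM to 7500 nM.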

Compound 4, half-maximal inhibitory concentration: 5500 nM
Estimate against measurement, compound 4: 2.1-fold (0.33 log units) below, and the stated range covers the measured number.
By their numbers in this assay, from the lowest: compounds 1 and 3 (each within the scatter of the next); then compounds 2 and 4 (each within the scatter of the next).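

In this assay the 3,4-dichlorophenyl group on the amide-type nitrogen gives a 4.6-fold higher number from compound 3 to compound 4 (0.66 log units; beyond the scatter) and a 6.5-fold higher number from compound 1 to compound 4 (0.82 log units; beyond the scatter) while a 1.4-fold higher number from compound 2 to compound 4 (0.15 log units; within the scatter) shows no separation from the 2,4-difluorophenyl amide. Among these four compounds, the two halogenated phenyl amides, compound 2 and compound 4, therefore share the higher numbers, and the 6-fluoropyridin-2-yl and 4-methyl-1,3-benzothiazol-2-yl amides, compound 1 and compound 3, share the lower numbers. Nothing available gives a cause for these steps. Still open, on these data alone, is whether a phenyl ring carrying an amine or a carboxylic acid would group with compound 2 and compound 4 or with compound 1 and compound 3.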